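From 2-methylphenyl to 4-methylphenyl at the assay limit

The source may report more compounds than this note shows. Statements on the series, on what has been measured and on what is new or still open speak of the compounds shown alone.

In a functional assay on SGC-7901 cells (Homo sapiens) for antiproliferative activity, read by MTT assay, with a stated time of 24 h (a lower number here means a stronger inhibitor, a higher number a weaker inhibitor), compound 1 `Cc1cccc(NNC(=O)c2cccc(NS(=O)(=O)c3cnc(O)nc3O)c2)c1` reads > 20000 nM and that is a limit of the assay, not a number. Compound 2 `Cc1ccccc1C(=O)NNC(=O)c1cccc(NS(=O)(=O)c2cnc(O)nc2O)c1` reads > 20000 nM and that too is only a limit, so no number places it. Within the data shown here, the one measured step (a step that the two limits leave unreadable from compound 1 to compound 2) gives no readable size. Among the measured compounds shown here, compound 3 `Cc1ccc(C(=O)NNC(=O)c2cccc(NS(=O)(=O)c3cnc(O)nc3O)c2)cc1` carries 4-methylphenyl in place of 2-methylphenyl on a carbonyl carbon and no measured step covers that change. Compound 1 and compound 2 both sit at one limit (the limit of > 20000 nM in this assay, at which 2 of the 2 values shown sit) so no step beyond the scatter is expected in this assay and no direction can be given. The estimated step (a step that the limit leaves unreadable from compound 2 to compound 3) follows that expectation, and a further limit is the likeliest report. For compound 3 the estimate is 25000 nM with an expected range from 12000 nM to 50000 nM overall.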

Compound 3, half-maximal inhibitory concentration: 10100 nM
Compound 3: middle estimate off by 2.5-fold (0.39 log units), on the high side; measured number outside the range, below it.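

In this assay, among these compounds, compound 3 is the only one of the three compounds to give a number and not a limit: the limit of > 20000 nM in this assay, at which 2 of the 3 values shown sit. Placing 4-methylphenyl in place of 2-methylphenyl on a carbonyl carbon gives an at least 1.9-fold lower number from compound 2 to compound 3 (0.29 log units; that floor lies within the scatter), and the other change in one place that ends in the same structure gives an at least 1.9-fold lower number from compound 1 to compound 3 (0.29 log units; that floor lies within the scatter), so neither printed floor alone shows a change beyond the scatter. The step from compound 1 to compound 2 lies between two limits and cannot be read.

The compounds shown leave open how 3-methylphenyl on the same carbonyl carbon would read in this assay. They also leave open whether an amine or a carboxylic acid in place of the methyl of 4-methylphenyl would still give a number there.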